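This account rests on a few compounds, and the source may have more. Where it says the series, first, only, none or still open, it means among the compounds named here.

Compound 1 `CCCCC1CCC(OC(=O)N[C@@H](CC(C)C)C(=O)N[C@@H](C[C@@H]2CCNC2=O)C(O)S(=O)(=O)O)CC1` and compound 2 `CCCC1CCC(OC(=O)N[C@@H](CC(C)C)C(=O)N[C@@H](C[C@@H]2CCNC2=O)C(O)S(=O)(=O)O)CC1` share one core and differ at a single place. In a toxicity assay on L929 cells (Mus musculus) for cytotoxicity (a lower number here means that less compound is tolerated, a higher number that more compound is tolerated), compound 1 gives 59100 nM. Compound 2 reaches only the limit of this assay, > 100000 nM, so its standing is known as a limit and not as a number. Going by the values given here, the step of an at least 1.6-fold higher number from compound 1 to compound 2 (0.22 log units; that floor lies within the scatter) is the only measured step in the set; it rests on the limit of > 100000 nM in this assay, at which 1 of the 2 values shown sits, and cannot be sized beyond its floor. Compound 3 `CC(C)C[C@H](NC(=O)OC1CCC(F)(F)CC1)C(=O)N[C@@H](C[C@@H]1CCNC1=O)C(O)S(=O)(=O)O` differs from compound 2 by 4,4-difluorocyclohexyl in place of 4-propylcyclohexyl on an oxygen next to a carbonyl group. Among the compounds with values here, no measured step covers this exchange; the one step that was measured removed a methyl from the chain and carried the value to the limit. The exchange of the whole 4-propylcyclohexyl for 4,4-difluorocyclohexyl is a larger alteration, and no direction beyond the scatter can be read from the data for it. For this assay compound 3 is expected to remain at or beyond the limit, with a step of a number no higher from compound 2 to compound 3 (the limit leaves the size open) expected. The estimate for compound 3 in this assay is 100000 nM, expected to fall between 40000 nM and 300000 nM.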

Compound 3, half-maximal cytotoxic concentration: > 100000 nM
Compound 3 ended at the assay's limit (the forecaster's own chance of this, stated with the estimate: 70%); the middle value lies on the limit itself.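

On an oxygen next to a carbonyl group, 4,4-difluorocyclohexyl is a second group after 4-propylcyclohexyl to reach the limit: in this assay compound 3 gives > 100000 nM, which is a limit of the assay and not a number. Against the group of 10 heavy atoms in compound 1, the exchange gives an at least 1.6-fold higher number from compound 1 to compound 3 (0.22 log units; that floor lies within the scatter), so this step alone sets no direction beyond the scatter. The step between compound 2 and compound 3 cannot be read, because both stand at the same limit: the limit of > 100000 nM in this assay, at which 2 of the 3 values shown sit.

Going by these compounds, how far compound 2 and compound 3 lie past the limit stays open, and with it any order between 4-propylcyclohexyl and 4,4-difluorocyclohexyl at this position. Also open is whether a longer chain on the cyclohexyl ring, a phenyl ring or an amine at the same place would give a measured number rather than a limit, since compound 1 is so far the only compound shown with a number in this assay.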